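The compounds below may be only part of what the source reports. "The series", "measured", "known", "first", "only" and "open" are said of these compounds alone.

The measured compounds:
compound 1, `CNc1cc(C)c2cc(NC(=O)c3ccc(Cl)c(Cl)c3)ccc2n1`, with 6350 nM in a functional assay on SK-BR-3 cells (Homo sapiens) for antiproliferative activity, read by MTT assay, with a stated time of 72 h; on this read-out higher numbers stand for weaker inhibition and lower numbers for stronger inhibition
compound 2, `CCN1CCN(c2cc(C)c3cc(NC(=O)c4ccccc4C)ccc3n2)CC1`, with 29200 nM
compound 3, `Cc1cc(N2CCCC2)nc2ccc(NC(=O)c3ccc(Cl)c(Cl)c3)cc12`, with 43400 nM

Compound 2 stands second highest of the three numbers. Its nearest neighbour is compound 3, and the two lie within the scatter of each other, so no order between them can be claimed; compound 1 stands further off, beyond the scatter on the lower side. Within the data shown here, the only step between measured compounds that differ in one place is a 6.8-fold higher number from compound 1 to compound 3 (0.83 log units; beyond the scatter), and it concerns the substituent on the aromatic carbon of the shared core, not the amide portion.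

Compound 4, `CCN1CCN(c2cc(C)c3cc(NC(=O)c4cccc(Br)c4)ccc3n2)CC1`, differs from compound 2 in that amide portion: 3-bromophenyl in place of 2-methylphenyl on a carbonyl carbon. Among the measured compounds shown here, no measured step bears on this change, and the two compounds that carry a halogenated amide differ from compound 2 elsewhere as well: compound 3 gives 43400 nM and compound 1 gives 6350 nM, numbers on both sides of compound 2. For the measured compounds named here, with no direct precedent, the step of a 1.3-fold lower number from compound 2 to compound 4 (0.12 log units; within the scatter) is expected to stay within the scatter. Compound 4 is therefore estimated at 22000 nM, with a range from 6000 nM to 60000 nM.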

Compound 4, half-maximal inhibitory concentration: 13300 nM
Compound 4: the middle estimate sits 1.7-fold (0.22 log units) above what was measured, and the stated range covers the measured number.
By their numbers in this assay, from the lowest: compound 1; then compound 4; then compounds 2 and 3 (each within the scatter of the next).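

In this assay, with the rest of the structure held the same, the group on the carbonyl carbon proves able to shift the number: 3-bromophenyl in place of 2-methylphenyl gives a 2.2-fold lower number from compound 2 to compound 4 (0.34 log units; beyond the scatter), a modest step but one beyond the scatter. Among these compounds, until this pair, the only single-place step concerned the substituent on the aromatic carbon of the shared core, a 6.8-fold higher number from compound 1 to compound 3 (0.83 log units; beyond the scatter), so this is the first direct reading of a change in the amide portion. The two groups match in heavy-atom count and in their counts of hydrogen-bond donors and acceptors, so those counts do not separate them, and no measurement at hand accounts for the step.

The compounds shown leave open whether the step follows the bromine or the place of the substituent, as 2-methylphenyl and 3-bromophenyl differ in both; 3-methylphenyl or 2-bromophenyl on the same carbonyl carbon would tell the two apart. Also open, on these data alone, are how 3-aminophenyl or 3-carboxyphenyl would read at this place and whether the step would carry over to the methylamino series of compound 1.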